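The source may hold more compounds than are shown below. What is called first, only, known or untested is meant among the compounds shown, and "the series" means these compounds.

Working notes on the series, read in a functional assay on MCF7 cells (Homo sapiens) for antiproliferative activity; on this read-out higher numbers stand for weaker inhibition and lower numbers for stronger inhibition. Compound 1 (`CC(C)=CCc1cc(C(=O)Nc2cc3ccc(OCCCN4CCCC4)c(C)c3oc2=O)ccc1O`) gives 990 nM and compound 2 (`CCNCCCOc1ccc2cc(NC(=O)c3ccc(O)c(CC=C(C)C)c3)c(=O)oc2c1C`) gives 980 nM. That pair shows no real change, with a 1.0-fold lower number from compound 1 to compound 2 (0.00 log units; within the scatter). Compound 3 (`CC(C)=CCc1cc(C(=O)Nc2cc3ccc(OCCCNCC(=O)O)c(C)c3oc2=O)ccc1O`) gives 18100 nM, the highest number of the three and so the weakest inhibition here.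

Compound 4 (`CC(C)=CCc1cc(C(=O)Nc2cc3ccc(OCCCNCCO)c(C)c3oc2=O)ccc1O`) differs from compound 3 by one change: hydroxymethyl in place of carboxy on a saturated chain carbon bound to an amine nitrogen, with hydroxymethyl in place of carboxy on a saturated chain carbon bound to an amine nitrogen.

The nearest measured step places carboxy on that same kind of carbon, in place of methyl, and it is large: an 18-fold higher number from compound 2 to compound 3 (1.27 log units; beyond the scatter). The pyrrolidin-1-yl comparison gives a step of similar size: an 18-fold higher number from compound 1 to compound 3 (1.26 log units; beyond the scatter). Carboxy leaves in the new change, so a large step to a lower number is expected, towards compound 2 at 980 nM. Going by the values given here, no measured compound carries hydroxymethyl, so a full return is not assured.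

The expected step is a 10-fold lower number from compound 3 to compound 4 (1.00 log units; beyond the scatter). The estimate for compound 4 is 1800 nM, with an expected range of 800 nM to 6000 nM.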

Compound 4, half-maximal inhibitory concentration: 1560 nM
Compound 4: middle estimate off by 1.2-fold (0.06 log units), on the high side, and the stated range covers the measured number.
By their numbers in this assay, from the lowest: compounds 2, 1 and 4 (each within the scatter of the next); then compound 3.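

The large drop in the number with a 12-fold lower number from compound 3 to compound 4 (1.06 log units; beyond the scatter) shows that the weak result of compound 3 does not extend to every oxygen-bearing group on this saturated chain carbon bound to an amine nitrogen; among these compounds, it goes with carboxy. Hydroxy is tolerated on the chain, since a 1.6-fold higher number from compound 2 to compound 4 (0.20 log units; within the scatter) and a 1.6-fold higher number from compound 1 to compound 4 (0.20 log units; within the scatter) both stay within the scatter, leaving (2-hydroxyethyl)amino level with ethylamino and pyrrolidin-1-yl. No measurement on hand explains the gap between carboxy and hydroxymethyl.

As far as these compounds go, whether a primary carboxamide or a methyl ester in place of carboxy would track compound 4 or compound 3 remains open. So does whether a longer chain, such as 3-hydroxypropyl on the amine nitrogen, or a tertiary amine carrying 2-hydroxyethyl would stay level with compound 4.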